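Cyclohexyl for dimethylphenyl in a quinoline solubility series

The source may report more compounds than this note shows. Statements on the series, on what has been measured and on what is new or still open speak of the compounds shown alone.

Three compounds share one core: compound 1 `COc1ccc(F)cc1CNCCCNc1ccnc2cc(Cc3cc(C)cc(C)c3)ccc12`, compound 2 `COc1cccc(CNCCCNc2ccnc3cc(Cc4ccccc4)ccc23)c1O` and compound 3 `Cc1cc(C)cc(Cc2ccc3c(NCCCNCc4ccco4)ccnc3c2)c1`. In a physicochemical assay for solubility, with a stated time of 18 h, at pH 7.4 (on this read-out higher numbers stand for higher solubility and lower numbers for lower solubility), compound 1 gives 4200 nM, compound 2 gives 4200 nM and compound 3 gives 4200 nM, so compound 3 stands level with both. For the measured compounds named here, the one step measured, no change at the digits printed from compound 1 to compound 3 (within the scatter), concerns the amine side of the molecule. Compound 4 `c1coc(CNCCCNc2ccnc3cc(CC4CCCCC4)ccc23)c1` differs from compound 3 elsewhere: cyclohexyl in place of 3,5-dimethylphenyl on a saturated chain carbon bound to an aromatic carbon. Going by the values given here, no measured step covers this part of the structure, so the only guide is the flat behaviour seen so far. Compound 4 is therefore expected to stay within the scatter, with no change at the digits printed from compound 3 to compound 4 (within the scatter). The estimate for compound 4 in this assay is 4200 nM, ranging from 1500 nM to 12000 nM.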

Compound 4, solubility: 4200 nM
For compound 4 middle estimate and measured number coincide at the digits printed, and the stated range covers the measured number.
By their numbers in this assay, from the lowest: compounds 1, 2, 3 and 4 (each within the scatter of the next).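

The change to cyclohexyl from 3,5-dimethylphenyl reads no change at the digits printed from compound 3 to compound 4 (within the scatter) in this assay and gives this position a step of its own, where the earlier step concerned only the amine side. Here, a non-aromatic ring of carbon only with 6 heavy atoms and an aromatic one with 8 read alike. No evidence at hand explains this flat step.

As far as these compounds go, whether an amine or a carboxylic acid on the ring at this place would read the same stays open. So does whether a longer chain in place of the saturated chain carbon would.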